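The compounds below may be only part of what the source reports. "The series", "measured", "known", "first", "only" and "open" are said of these compounds alone.

Working notes on the series.

Compound 1 `O=Cc1ccc(-c2cn3ccnc3c(-c3ccc4ncn(C5CCCCC5)c4c3)n2)cc1` is the reference point. In a functional assay on HCT-116 cells (Homo sapiens) for inhibition, read by sulforhodamine B assay, with a stated time of 48 h, tested at 10 uM (on this read-out higher numbers stand for more inhibition at the one concentration tested (going by the name of the read-out) and lower numbers for less inhibition), compound 1 gives 92.6%. Compound 2 `O=Cc1ccc(-c2cn3ccnc3c(-c3ccc4ncn(Cc5ccccc5)c4c3)n2)cc1` carries the change benzyl in place of cyclohexyl on an aromatic nitrogen relative to compound 1, and in this assay compound 2 gives 92.6%. For the measured compounds named here, the step of no change at the digits printed from compound 1 to compound 2 (within the scatter) is the only directly measured instance so far of swapping cyclohexyl for benzyl on the ring nitrogen, and it moves the read-out by nothing that can be told from the scatter.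

Compound 3 `c1cn2cc(-c3ccc4c(c3)ncn4C3CCCCC3)nc(-c3ccc4ncn(C5CCCCC5)c4c3)c2n1` has a different core from compound 1; how the two cores differ is not broken down here. In this assay compound 3 gives 29.1%, the lowest of the three numbers and well separated from both compound 1 and compound 2.

Compound 4 `c1ccc(Cn2cnc3ccc(-c4nc(-c5ccc6c(c5)ncn6C5CCCCC5)cn5ccnc45)cc32)cc1` is not yet measured. Relative to compound 3 it carries the change (benzyl in place of cyclohexyl on an aromatic nitrogen), the same change as from compound 1 to compound 2, made at a place described in identical words. Going by the values given here, on the only evidence available, the step of no change at the digits printed from compound 1 to compound 2 (within the scatter), the swap is expected to leave the read-out essentially where compound 3 sits, so the expected step is a number 0.9 percentage points higher from compound 3 to compound 4 (within the scatter). Among the compounds with values here, with that, compound 4 is estimated to give 30% in this assay, with an expected range from 12% to 55%; the single prior instance of the change means the range is kept wide.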

Compound 4, a percentage reported as inhibition, at one concentration (the size of the read-out at that concentration, not a potency): -75.8%
Beside the measured number, compound 4's estimate is 105.8 percentage points above it; the whole stated range lies above it.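

In this assay, benzyl in place of cyclohexyl on the aromatic nitrogen gives a number 104.9 percentage points lower from compound 3 to compound 4 (beyond the scatter), a step that stands in sharp contrast to the earlier pair. The result of this swap therefore depends on the core carrying it, at least across the two cores shown, and the step measured on one core cannot be transferred to the other: the same change on two cores in this assay, no change at the digits printed (within the scatter) from compound 1 to compound 2 and a number 104.9 percentage points lower (beyond the scatter) from compound 3 to compound 4, 104.9 percentage points apart, beyond the scatter of two such steps This does not show which feature of the two cores separates the outcomes, since the cores differ in a way not broken down here and only two pairs are available, nor does it give any cause for the difference or a rule for a further core.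

Only cyclohexyl and benzyl stand on the ring nitrogen in the compounds shown, so it remains open how a methyl group, a longer chain, or a chain ending in an amine or a carboxylic acid would read on either core. From the compounds shown here alone, it also remains open whether the swap on a third core would follow the pair from compound 1 to compound 2 or the pair from compound 3 to compound 4, or neither.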